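Swapping the aryl ring on a thiazolidinone core

The source may hold more compounds than are shown below. What is called first, only, known or untested is meant among the compounds shown, and "the series" means these compounds.

In an ADME assay on Vero cells (Chlorocebus sabaeus) for cytotoxicity, read by neutral red uptake, tested at 1575 ug/mL (on this read-out higher numbers stand for a weaker effect at the one concentration tested and lower numbers for a stronger effect), compound 2 `O=C1CSC(c2ccc(O)cc2)N1CCN1CCCCC1` gives 12%, and compound 1 `COc1ccc(C2SCC(=O)N2CCN2CCCCC2)cc1` gives 11%, so the two numbers lie within the scatter of each other, as the step of a number 1 percentage points higher from compound 1 to compound 2 (within the scatter) shows. Compound 3 `O=C1CSC(c2ccccc2Cl)N1CCN1CCCCC1` differs from compound 2 by 2-chlorophenyl in place of 4-hydroxyphenyl on a saturated ring carbon. For the measured compounds named here, the one measured step, hydrogen in place of methyl on an oxygen on an aromatic ring, altered the same aryl group and stayed within the scatter; no measured step exchanges the whole ring. Compound 3 is therefore expected to move little, with an estimated no change at the digits printed from compound 2 to compound 3 (within the scatter). The estimate for compound 3 is 12%, within a range from 2% to 25%.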

Compound 3, a percentage reported as activity, at one concentration (the size of the read-out at that concentration, not a potency): 16%
Compound 3: the middle estimate sits 4 percentage points below what was measured; measured number inside the range.
By their numbers in this assay, from the lowest: compounds 1, 2 and 3 (each within the scatter of the next).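

In this assay, replacing the whole 4-hydroxyphenyl group with 2-chlorophenyl on the saturated ring carbon gives a number 4 percentage points higher from compound 2 to compound 3 (within the scatter). This position therefore accepts more than the small change to the oxygen substituent seen earlier: the incoming group has no hydrogen-bond donor or acceptor, yet the step stays within the scatter. No available measurement explains this result.

Still open, going by these compounds, is whether a phenyl ring carrying an amine or a carboxylic acid would also stay within the scatter. A longer alkyl chain in place of the ring is equally untested by the compounds shown.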